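The source may hold more compounds than are shown below. What is called first, only, known or untested is meant among the compounds shown, and "the series" means these compounds.

Compound 1, `CO/N=C(\C)c1ccccc1NCC1=NCCN1`, in a functional assay for activation of Alpha-1D adrenergic receptor (Homo sapiens); a lower number here means that less compound is needed, a higher number that more compound is needed for the effect: < 5020 nM, a limit of the assay.
Compound 2, `CC/C(=N\OC)c1ccccc1NCC1=NCCN1`, in this assay: < 100000 nM, also a limit.

As far as these compounds go, compound 2 stands at the limit of < 100000 nM in this assay, at which 1 of the 2 values shown sits, so its own number is unknown. Compound 1 rests at the limit of < 5020 nM in this assay, at which 1 of the 2 values shown sits. Among the compounds with values here, the one measured step, a step that the two limits leave unreadable from compound 1 to compound 2, therefore cannot be sized. Compound 3, `CO/N=C/c1ccccc1NCC1=NCCN1`, arises through (a group of 4 heavy atoms (2 carbon, 1 nitrogen, 1 oxygen; no ring) in place of a group of 6 heavy atoms (4 carbon, 1 nitrogen, 1 oxygen; no ring), on an aromatic carbon). Within the data shown here, no measured step bears on this change, so the direction and size of a step that the limit leaves unreadable from compound 2 to compound 3 are expected only loosely. Compound 3 is estimated at 3000 nM, within 300 nM to 30000 nM.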

Compound 3, half-maximal effective concentration: < 5020 nM
Compound 3 gave a limit, no number; the forecaster's own chance of this, stated with the estimate: 40%; the middle value does not contradict the limit.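

Within the data shown here, compound 3 gives a limit rather than a number, as do compound 1 and compound 2, so no step among them can be read. The compounds shown leave open whether changing the group on the aromatic carbon shifts the concentration needed.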